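Benzyl groups on the ring amine of the shared core

A few compounds are considered here, and "the series" means these few. Any claim that something is new, unique, unknown or untested is made for them only; others in the source may bear on it.

Compound 1 `NC(=O)c1c(NC(=O)c2ccccc2Cl)sc2c1CCNC2` carries a free amine nitrogen in a ring of its shared core. In a functional assay on HeLa cells (Homo sapiens) for antiproliferative activity, with a stated time of 24 h (a higher number here means a weaker inhibitor, a lower number a stronger inhibitor), compound 1 gives 45000 nM, which stands highest of the two numbers in hand, with compound 3 nearest. Compound 2 `Cc1ccccc1CN1CCc2c(sc(NC(=O)c3ccccc3Cl)c2C(N)=O)C1` places a 2-methylbenzyl on that nitrogen. In this assay compound 2 reports only a limit of the assay, > 50000 nM, and so sits at the limit of > 50000 nM in this assay, at which 1 of the 3 values shown sits. Compound 3 `NC(=O)c1c(NC(=O)c2ccccc2Cl)sc2c1CCN(Cc1c(Cl)cccc1Cl)C2` places a 2,6-dichlorobenzyl on the same nitrogen and in this assay compound 3 gives 28800 nM. The measured steps are an at least 1.1-fold higher number from compound 1 to compound 2 (0.04 log units; that floor lies within the scatter), a 1.6-fold lower number from compound 1 to compound 3 (0.19 log units; within the scatter) and an at least 1.7-fold lower number from compound 2 to compound 3 (0.23 log units; that floor lies within the scatter), none of them beyond the scatter.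

Compound 4 `NC(=O)c1c(NC(=O)c2ccccc2Cl)sc2c1CCN(Cc1cc(Cl)cc(Cl)c1)C2` adds a third benzyl variant to the same position: 3,5-dichlorobenzyl in place of hydrogen on an amine nitrogen in a ring. Within the data shown here, the steps that bear on it are those from compound 1 to compound 2 and from compound 1 to compound 3, both staying within the scatter, so in this assay no movement beyond the scatter is expected in either direction, with some chance that compound 4 also returns only a limit. The step from compound 1 to compound 4 is therefore expected to be a 1.3-fold lower number from compound 1 to compound 4 (0.11 log units; within the scatter). For compound 4 the expected value in this assay is 35000 nM, within a range of 15000 nM to 80000 nM.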

Compound 4, half-maximal inhibitory concentration: 19600 nM
Beside the measured number, compound 4's estimate is 1.8-fold (0.25 log units) above it; the measured number falls inside the stated range.
By their numbers in this assay, from the lowest: compounds 4, 3 and 1 (each within the scatter of the next, the first and the last beyond it). At a limit, above all of these: compound 2.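

In this assay, the 3,5-dichlorobenzyl group gives the first step from the free amine nitrogen in a ring that passes the scatter, a 2.3-fold lower number from compound 1 to compound 4 (0.36 log units; beyond the scatter), though only modestly; the steps to the two earlier benzyl variants did not establish any shift. The exchange of 2,6-dichlorophenyl for 3,5-dichlorophenyl gives a 1.5-fold lower number from compound 3 to compound 4 (0.17 log units; within the scatter), so this pair cannot be separated, and the two chlorine patterns cannot be ranked on these data. Against the 2-methylphenyl group, the change reads an at least 2.5-fold lower number from compound 2 to compound 4 (0.40 log units; beyond the scatter), and this is only a floor, compound 2 being a limit of the assay: the limit of > 50000 nM in this assay, at which 1 of the 4 values shown sits.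

Open, on these data alone, is whether the modest shift seen with compound 4 belongs to the chlorines or to the benzyl group as a whole, a question that an unsubstituted benzyl or a 3-chlorobenzyl on the same nitrogen would bear on. Also open, as far as these compounds go, is how this position responds to substituents of another kind, such as an acetyl group, a longer phenethyl chain or a benzyl carrying a carboxylic acid.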